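From phenyl to 2,4-dichlorophenyl in a cytotoxicity series

The source may report more compounds than this note shows. Statements on the series, on what has been measured and on what is new or still open speak of the compounds shown alone.

Of the compounds shown here, three sharing one core have been measured in a functional assay on A549 cells (Homo sapiens) for cytotoxicity, read by MTT assay, with a stated time of 72 h; a lower number here means a stronger inhibitor, a higher number a weaker inhibitor. Compound 3 `CNC(=O)c1cc(Oc2ccc(C(=O)/C=C/c3ccccc3)cc2)ccn1`, the unsubstituted phenyl member, gives 5040 nM, the lowest of the numbers shown. Compound 2 `CNC(=O)c1cc(Oc2ccc(C(=O)/C=C/c3ccc(C#N)cc3)cc2)ccn1`, which carries cyano on an aromatic carbon, gives 26400 nM. Compound 1 `CNC(=O)c1cc(Oc2ccc(C(=O)/C=C/c3ccc(Br)cc3)cc2)ccn1`, which carries bromo there, reads > 50000 nM, and this is a limit of the assay, not a number.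

Compound 4 `CNC(=O)c1cc(Oc2ccc(C(=O)/C=C/c3ccc(Cl)cc3Cl)cc2)ccn1` has 2,4-dichlorophenyl in place of phenyl on a double-bonded chain carbon bound to a double-bonded chain carbon. Among the compounds with values here, two measured steps bear on this change: an at least 9.9-fold lower number from compound 1 to compound 3 (0.99 log units; beyond the scatter) and a 5.2-fold lower number from compound 2 to compound 3 (0.72 log units; beyond the scatter). Read in reverse, both show a substituted ring giving a higher number than the phenyl of compound 3, and neither of the other measured compounds goes against this. Within the data shown here, no chloro compound has been measured, so the size remains uncertain. A higher number is expected, with the expected step being a 3.6-fold higher number from compound 3 to compound 4 (0.55 log units; beyond the scatter). For compound 4 the estimate is 18000 nM, with an expected range from 6000 nM to 50000 nM.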

Compound 4, half-maximal inhibitory concentration: 9460 nM
The estimate for compound 4 lay 1.9-fold (0.28 log units) above the measured number, within the range that was stated.
By their numbers in this assay, from the lowest: compounds 3 and 4 (each within the scatter of the next); then compound 2. At a limit, above all of these: compound 1.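

In this assay, a substituted ring at this place on the double-bonded chain carbon need not separate from phenyl, as the step to 2,4-dichlorophenyl shows: a 1.9-fold higher number from compound 3 to compound 4 (0.27 log units; within the scatter). Substitution at this place therefore does not by itself set the number, for 2,4-dichlorophenyl also parts from the two singly substituted rings, with a 2.8-fold lower number from compound 2 to compound 4 (0.45 log units; beyond the scatter) and an at least 5.2-fold lower number from compound 1 to compound 4 (0.72 log units; beyond the scatter). The second of these steps is only a floor because compound 1 reads at a limit and not at a number: the limit of > 50000 nM in this assay, at which 1 of the 4 values shown sits.

The compounds shown leave open what a ring with a single chlorine would give, and so how each of the two chlorines contributes to the value of compound 4. They also leave open whether a methoxy or dimethylamino group on this ring would read any differently from phenyl.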